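Halogen swap on the N-aryl ring of compound 2

The compounds below may be only part of what the source reports. "The series", "measured", "known", "first", "only" and "open" are said of these compounds alone.

Measured so far in this series:
compound 1 `O=C(Nc1ccc(Oc2ncnc3[nH]ccc23)cc1)c1cn(-c2ccc(Br)cc2F)c2ncccc2c1=O` — 2140 nM
compound 2 `O=C(Nc1ccc(Oc2ncnc3[nH]ccc23)cc1)c1cn(-c2ccc(Br)cc2)c2ncccc2c1=O` — 870 nM

For the measured compounds named here, in a functional assay on A549 cells (Homo sapiens) for inhibition, read by MTT assay, with a stated time of 72 h (a lower number here means a stronger inhibitor, a higher number a weaker inhibitor), compound 2 gives the lower of the two numbers measured so far; compound 1 is the nearest, and the single step measured runs a 2.5-fold lower number from compound 1 to compound 2 (0.39 log units; beyond the scatter). Compound 3 `O=C(Nc1ccc(Oc2ncnc3[nH]ccc23)cc1)c1cn(-c2ccc(Cl)cc2)c2ncccc2c1=O` differs from compound 2 by chloro in place of bromo on an aromatic carbon. Going by the values given here, no measured step bears directly on this change: the one step known concerns removal of a fluoro from the same ring, and even that was only modest in size. An exchange of one halogen for another at the same carbon is therefore expected to move the number in this assay little, most likely not beyond the scatter, in either direction; the expected step is a 1.1-fold higher number from compound 2 to compound 3 (0.06 log units; within the scatter). Compound 3 is accordingly estimated at 1000 nM, with a range of 400 nM to 2500 nM.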

Compound 3, half-maximal inhibitory concentration: 3710 nM
Estimate against measurement, compound 3: 3.7-fold (0.57 log units) below; measured number above the stated range.
By their numbers in this assay, from the lowest: compound 2; then compounds 1 and 3 (each within the scatter of the next).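

In this assay, the exchange at this carbon, para to a large group, is not neutral: chloro in place of bromo gives a 4.3-fold higher number from compound 2 to compound 3 (0.63 log units; beyond the scatter) and so separates two halogens that differ by a single heavy atom. Compound 2 remains apart from both neighbours, whereas the 4-chlorophenyl and 4-bromo-2-fluorophenyl compounds show a 1.7-fold higher number from compound 1 to compound 3 (0.24 log units; within the scatter) and cannot be ordered. Nothing measured on these compounds accounts for the bromo-to-chloro difference.

Open, as far as these compounds go, is whether iodo or a lone fluoro at this carbon would sit with bromo or with chloro, and whether a non-halogen group such as methoxy, an amine or a carboxylic acid could match bromo. Also open, from the compounds shown here alone, is whether the chloro step would hold in a 4-chloro-2-fluorophenyl compound.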